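Chloro-for-fluoro and ring position in a sulfonamide series

This account rests on a few compounds, and the source may have more. Where it says the series, first, only, none or still open, it means among the compounds named here.

Among the compounds with values here, compound 3 `O=c1[nH]cc(S(=O)(=O)Nc2ccccc2-c2cn(-c3ccccc3Cl)nn2)c(=O)[nH]1` is the one member with a full number in an ADME assay on L02 cells (Homo sapiens) for cytotoxicity, read by MTT assay, with a stated time of 24 h; a higher number here means that more compound is tolerated, a lower number that less compound is tolerated: compound 3 gives 22800 nM. Compound 1 `O=c1[nH]cc(S(=O)(=O)Nc2ccccc2-c2cn(-c3ccccc3F)nn2)c(=O)[nH]1` reaches only a limit of the assay, as compound 1 gives > 100000 nM; this is the limit described by the limit of > 100000 nM in this assay, at which 1 of the 3 values shown sits. Compound 2 `O=c1[nH]cc(S(=O)(=O)Nc2ccccc2-c2cn(-c3cccc(F)c3)nn2)c(=O)[nH]1` has no number, as compound 2 is recorded as "not toxic" (no number reported) in this assay. Within the data shown here, the one measured step, an at least 4.3-fold lower number from compound 1 to compound 3 (0.64 log units; beyond the scatter), is the change from fluoro to chloro and is the sole quantitative guide in the set.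

Compound 4 `O=c1[nH]cc(S(=O)(=O)Nc2ccccc2-c2cn(-c3ccc(Cl)cc3)nn2)c(=O)[nH]1` differs from compound 3 only in the position of the chlorine: 4-chlorophenyl in place of 2-chlorophenyl on an aromatic nitrogen. Among the measured compounds shown here, no measured step in this assay shows the effect of moving a substituent around the phenyl ring; the pair compound 1 and compound 2 shows a limit against an entry without a number, which cannot be turned into a step. The measured step bears on halogen identity, not on position, so for compound 4 no step beyond the scatter is expected in this assay, with the direction left open. The estimate for compound 4 is 30000 nM, between 10000 nM and 100000 nM, which corresponds to an expected step of a 1.3-fold higher number from compound 3 to compound 4 (0.12 log units; within the scatter).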

Compound 4, half-maximal cytotoxic concentration: 16800 nM
Estimate against measurement, compound 4: 1.8-fold (0.25 log units) above; low and high end bracket the measured number.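

In this assay, within the data shown here, the first reading of chlorine position gives a 1.4-fold lower number from compound 3 to compound 4 (0.13 log units; within the scatter), so 4-chlorophenyl and 2-chlorophenyl on the aromatic nitrogen are not told apart by this assay. The lower number seen earlier with chlorine therefore no longer rests on 2-chlorophenyl alone: the listed comparison with the fluoro compound gives an at least 5.9-fold lower number from compound 1 to compound 4 (0.77 log units; beyond the scatter), and both chlorine compounds now lie beyond the scatter from compound 1. The true size of either step remains unknown, and each can be read only as a bound, as compound 1 sits at a limit of the assay: the limit of > 100000 nM in this assay, at which 1 of the 4 values shown sits.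

On these data alone, whether ring position matters for fluorine stays open, as compound 2 carries only the entry "not toxic", and the two chlorine positions alone cannot show whether the tolerance of position extends to other halogens. The compounds shown also leave open how a bromine, a methoxy group or an amine on the phenyl ring would read in this assay, and whether any of these would sit with the fluoro compound or with the chlorine pair.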